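Sulfonamide nitrogen change from compound 1 to compound 4

The compounds below may be only part of what the source reports. "The series", "measured", "known", "first", "only" and "open" are said of these compounds alone.

Values so far in a functional assay on MDA-MB-435 cells (Homo sapiens) for antiproliferative activity, read by sulforhodamine B assay, with a stated time of 72 h; a higher number here means a weaker inhibitor, a lower number a stronger inhibitor:
- compound 1 `Cc1cc(C)nc(NS(=O)(=O)c2ccc(Nc3nncc4ccccc34)cc2)n1` gives 3.4 nM
- compound 2 `S=C(NNc1nncc2ccccc12)Nc1ccccc1` gives 74 nM
- compound 3 `COc1ccc(NC(=S)NNc2nncc3ccccc23)cc1` gives 88 nM

Compound 1 has the lowest of the three values, well clear of the other two. Compound 4 (`O=S(=O)(Nc1ccccn1)c1ccc(Nc2nncc3ccccc23)cc1`) departs from it as follows (pyridin-2-yl in place of 4,6-dimethylpyrimidin-2-yl on a sulfonamide nitrogen), with pyridin-2-yl in place of 4,6-dimethylpyrimidin-2-yl on a sulfonamide nitrogen. Among the measured compounds shown here, the only measured step (a 1.2-fold higher number from compound 2 to compound 3 (0.08 log units; within the scatter)) is a methoxy change elsewhere, within the scatter, and offers little guidance. For the measured compounds named here, no measured step touches this sulfonamide nitrogen. Compound 1 sits at the low end (3.4 nM), so a move toward a higher number seems the likelier direction. The expected change in this assay is modest (a 2.4-fold higher number from compound 1 to compound 4 (0.37 log units; beyond the scatter)). For compound 4 the estimated value is 8 nM (expected range 2 nM to 50 nM).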

Compound 4, half-maximal inhibitory concentration: 36 nM
Compound 4: middle estimate off by 4.5-fold (0.65 log units), on the low side; the measured number falls inside the stated range.
By their numbers in this assay, from the lowest: compound 1; then compound 4; then compounds 2 and 3 (each within the scatter of the next).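

In this assay, among the compounds shown here, the group on the sulfonamide nitrogen matters: pyridin-2-yl in place of 4,6-dimethylpyrimidin-2-yl gives a large step (an 11-fold higher number from compound 1 to compound 4 (1.02 log units; beyond the scatter)), whereas the only earlier step, a methoxy change in another part of the series, stayed within the scatter. This nitrogen substituent is therefore a sensitive point in the series. No measured evidence accounts for the size of this step.

The swap changes both the methyl groups and the ring nitrogen count, and these remain unseparated. A pyrimidin-2-yl or 4,6-dimethylpyridin-2-yl group on the same nitrogen would tell them apart.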